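The source may report more compounds than this note shows. Statements on the series, on what has been measured and on what is new or still open speak of the compounds shown alone.

The study tests two compounds in a functional assay on artery with platelet-activating factor receptor (Rattus norvegicus) as the target; a higher number here means that more compound is needed for the effect, a lower number that less compound is needed. Compound 1, `CCCCCCCCCCCCCCCCOCC1COC(COC(=O)N(Cc2ccccn2)C(C)=O)C1`, gives in this assay > 5 mg/kg, which is a limit of the assay and not a number. Compound 2, `CCCCCCCCCCCCCCC1COC(COCCCC[n+]2ccsc2)C1`, gives in this assay > 5 mg/kg, again a limit rather than a number. Compound 2 thus stands at the limit of > 5 mg/kg in this assay, at which 2 of the 2 values shown sit, with no number of its own to anchor a comparison. Compound 3, `CCCCCCCCCCCCCCC1COC(COCCCCCCC[n+]2ccsc2)C1`, has not yet been measured; it differs from compound 2 by a group of 8 heavy atoms (6 carbon, 1 nitrogen, 1 sulfur; one five-membered aromatic ring with 2 hetero atoms) in place of a group of 5 heavy atoms (3 carbon, 1 nitrogen, 1 sulfur; one five-membered aromatic ring with 2 hetero atoms), on a saturated chain carbon, four bonds along the chain from an oxygen on a saturated carbon. For the measured compounds named here, no step between measured compounds is available to size this change, and both measured values are limits. The expected step from compound 2 to compound 3 in this assay is a number no higher from compound 2 to compound 3 (the limit leaves the size open), which is taken as no change beyond the usual scatter. Compound 3 is accordingly estimated at 5 mg/kg, with a range from 2 mg/kg to 20 mg/kg, and a limit is judged the likelier outcome for it.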

Compound 3, dose for 50% inhibition: 1.5 mg/kg
Compound 3: the middle estimate sits 3.3-fold (0.52 log units) above what was measured; the whole stated range lies above it.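

Replacing the group of 5 heavy atoms (3 carbon, 1 nitrogen, 1 sulfur) with the group of 8 heavy atoms (6 carbon, 1 nitrogen, 1 sulfur), on a saturated chain carbon, four bonds along the chain from an oxygen on a saturated carbon, gives in this assay an at least 3.3-fold lower number from compound 2 to compound 3 (0.52 log units; beyond the scatter). For the compounds shown here, this is the first change at this position that registers in the assay, and both groups carry the same five-membered aromatic ring with 2 hetero atoms and the same net charge of +1, so they differ in their carbon count. The full size of the step remains open, since the value of compound 2 is a limit and not a number: the limit of > 5 mg/kg in this assay, at which 2 of the 3 values shown sit.

On these data alone, whether a longer chain at this position would lower the number further, or would reverse the step, remains open. So does whether a quaternary ammonium group could take the place of the five-membered aromatic ring without losing the value of compound 3.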